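Moving the ring nitrogen of a pyridyl oxazole ketone

This account rests on a few compounds, and the source may have more. Where it says the series, first, only, none or still open, it means among the compounds named here.

Measured so far:
Compound 1, `O=Cc1coc(C(=O)CCCCCCc2ccccc2)n1`: 55 nM
Compound 2, `O=C(CCCCCCc1ccccc1)c1nc(-c2ccccn2)co1`: 1.9 nM

Both compounds were tested in an assay on isolated protein for inhibition of Fatty-acid amide hydrolase 1 (Rattus norvegicus); on this read-out lower numbers stand for stronger inhibition and higher numbers for weaker inhibition. Among the compounds with values here, compound 2 stands at the lowest number of the two; its nearest neighbour is compound 1, and the only measured step, a 29-fold lower number from compound 1 to compound 2 (1.46 log units; beyond the scatter), is a large one.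

Compound 3, `O=C(CCCCCCc1ccccc1)c1nc(-c2cccnc2)co1`, keeps every atom of compound 2 but joins them differently: pyridin-3-yl in place of pyridin-2-yl on an aromatic carbon. Within the data shown here, the measured step from compound 1 to compound 2 concerns swapping a formyl for a pyridin-2-yl group, not moving the nitrogen within a pyridyl ring, so it does not bear directly on this change; no step in the data does. The shared core and the chain with the phenyl end are untouched. Among the measured compounds shown here, with no direct precedent, the expectation for compound 3 is a modest rise in the number, a 7.9-fold higher number from compound 2 to compound 3 (0.90 log units; beyond the scatter), estimated rather than measured.

Compound 3 is therefore expected to give about 15 nM in this assay, within a range of 4 nM to 60 nM.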

Compound 3, inhibition constant: 18 nM
Estimate against measurement, compound 3: 1.2-fold (0.08 log units) below; low and high end bracket the measured number.
By their numbers in this assay, from the lowest: compound 2; then compound 3; then compound 1.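

Moving the ring nitrogen, with no atom added or removed, is enough to change the result in this assay: the step is a 9.5-fold higher number from compound 2 to compound 3 (0.98 log units; beyond the scatter). This position on the shared core therefore responds not only to which kind of group sits there, as the swap from formyl showed, but also to how a pyridine ring is joined to the core. Pyridin-3-yl keeps part of the advantage over formyl, with a 3.1-fold lower number from compound 1 to compound 3 (0.49 log units; beyond the scatter), but no information here accounts for the difference between the two pyridyl groups.

The compounds shown leave open how pyridin-4-yl, or a plain phenyl ring with no ring nitrogen at all, would compare at this position, and so whether pyridin-2-yl is unusually favourable or pyridin-3-yl is unusually unfavourable. They also leave open whether the preference for pyridin-2-yl would hold with a shorter chain in place of the one ending in phenyl; all three compounds carry that same chain.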